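Chloro for Methyl on a Weakly Cytotoxic Compound

A few compounds are considered here, and "the series" means these few. Any claim that something is new, unique, unknown or untested is made for them only; others in the source may bear on it.

Measured so far:
- compound 1, `C=CCn1c(=O)/c(=C\c2cccc(C)c2)[nH]c(=O)/c1=C\c1ccccc1OC`: 20400 nM
- compound 2, `COc1ccccc1/C=c1\c(=O)[nH]/c(=C/c2ccccc2Cl)c(=O)n1C`: 300 nM
- compound 3, `C=CCn1c(=O)/c(=C\c2cccc(Br)c2)[nH]c(=O)/c1=C\c1cccc(Br)c1`: "not active" (no number reported)

Of the compounds shown here, three sharing one core have been tested in a functional assay on BGC-823 cells (Homo sapiens) for cytotoxicity, read by CCK-8 assay, with a stated time of 72 h; on this read-out higher numbers stand for weaker inhibition and lower numbers for stronger inhibition. Compound 1 gives 20400 nM, the highest of the two numbers reported, meaning the weakest inhibition among them. Compound 2 gives 300 nM, a far lower number that lies well beyond the scatter. Compound 3 is reported in this assay only as "not active" (no number reported), without a number. Compound 4, `C=CCn1c(=O)/c(=C\c2cccc(Cl)c2)[nH]c(=O)/c1=C\c1ccccc1OC`, has not yet been measured. It differs from compound 1 in one place: chloro in place of methyl on an aromatic carbon. Among the compounds with values here, nothing among the measured compounds isolates this single change, so the expectation rests on compound 1 alone. Because compound 1 gives 20400 nM, and the swap of one small group for another of the same size is modest, the step of a 1.4-fold lower number from compound 1 to compound 4 (0.13 log units; within the scatter) is expected to stay within the scatter. Compound 4 is therefore estimated at 15000 nM, with a range from 5000 nM to 50000 nM.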

Compound 4, half-maximal inhibitory concentration: 4600 nM
Beside the measured number, compound 4's estimate is 3.3-fold (0.51 log units) above it, outside the stated range (below it).
By their numbers in this assay, from the lowest: compound 2; then compound 4; then compound 1.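

Changing 3-methylphenyl to 3-chlorophenyl gives a 4.4-fold lower number from compound 1 to compound 4 (0.65 log units; beyond the scatter) in this assay, and this is the first pair shown that differs in only one place, giving the first direct reading of this position. Exchanging one heavy atom for another, with no ring, hydrogen-bond donor, hydrogen-bond acceptor or net charge entering or leaving, is enough to move the number past the usual scatter, so the group at this position matters on this read-out. No measurement shown gives a reason for this step.

The compounds shown leave open how a fluoro group, an amine or a carboxylic acid at this position would compare, and whether the same swap would have a similar effect elsewhere on the shared core. Compound 2 and compound 3 differ from compound 1 in more than one place, so they cannot settle either question.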